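Swapping the sulfur-linked aryl group: expected cell toxicity

The source may report more compounds than this note shows. Statements on the series, on what has been measured and on what is new or still open speak of the compounds shown alone.

Compound 1, `Cc1cc(N2CC[C@@H](C)[C@@H](N(C)c3ncnc4[nH]ccc34)C2)n2nc(SCc3csc4ccc(Cl)cc34)nc2n1`: in a toxicity assay on GES1 cells (Homo sapiens) for inhibition, read by MTT assay, with a stated time of 72 h (on this read-out lower numbers stand for stronger inhibition and higher numbers for weaker inhibition), compound 1 gives > 100000 nM, which is a limit of the assay and not a number.
Compound 2, `Cc1cc(N2CC[C@@H](C)[C@@H](N(C)c3ncnc4[nH]ccc34)C2)n2nc(SCc3cc(Cl)ccc3Cl)nc2n1`: compound 2 gives 87500 nM.
Compound 3, `Cc1cc(N2CC[C@@H](C)[C@@H](N(C)c3ncnc4[nH]ccc34)C2)n2nc(SCc3ccc(Br)cc3)nc2n1`: compound 3 gives 55600 nM.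

Compound 1 therefore stands only at a limit of this assay; the other two compounds give measured numbers, and the limit of > 100000 nM in this assay, at which 1 of the 3 values shown sits, marks where compound 1 sits. Compound 4, `Cc1cc(N2CC[C@@H](C)[C@@H](N(C)c3ncnc4[nH]ccc34)C2)n2nc(SCc3ccc([N+](=O)[O-])cc3)nc2n1`, has not yet been measured in this assay. Its structure differs from compound 1 in one place: 4-nitrophenyl in place of 5-chloro-1-benzothiophen-3-yl on a saturated chain carbon bound to a sulfur.

Going by the values given here, the steps that bear on this change all start from the same position on the shared core. From compound 1 the steps were an at least 1.1-fold lower number from compound 1 to compound 2 (0.05 log units; that floor lies within the scatter) and an at least 1.7-fold lower number from compound 1 to compound 3 (0.25 log units; that floor lies within the scatter), and between the two measured numbers the step was a 1.6-fold lower number from compound 2 to compound 3 (0.20 log units; within the scatter). Among the compounds with values here, none of these lies beyond the scatter, so swapping the group at this position has so far given no step that can be told apart from noise. For compound 4 the expectation is therefore a number near the measured compounds, with a fair chance that this assay reports only a limit again: the expected step is an at least 1.3-fold lower number from compound 1 to compound 4 (0.12 log units; that floor lies within the scatter). Compound 4 is thus estimated at 75000 nM, within a range from 40000 nM to 150000 nM.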

Compound 4, half-maximal inhibitory concentration: 36600 nM
Estimate against measurement, compound 4: 2.0-fold (0.31 log units) above; measured number below the stated range.
By their numbers in this assay, from the lowest: compounds 4, 3 and 2 (each within the scatter of the next, the first and the last beyond it). At a limit, above all of these: compound 1.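

In this assay, changing the aryl group on a saturated chain carbon bound to a sulfur now gives steps that stand clear of the noise: 4-nitrophenyl in place of 5-chloro-1-benzothiophen-3-yl gives an at least 2.7-fold lower number from compound 1 to compound 4 (0.43 log units; beyond the scatter) and 4-nitrophenyl in place of 2,5-dichlorophenyl gives a 2.4-fold lower number from compound 2 to compound 4 (0.38 log units; beyond the scatter) as the second such step. Nitro in place of bromo on an aromatic carbon gives a 1.5-fold lower number from compound 3 to compound 4 (0.18 log units; within the scatter) and so does not set compound 4 apart from compound 3. This position can therefore shift the toxicity read-out, although only some swaps do so, and the step from compound 1 is a floor and not a full size, because compound 1 rests on a limit of the assay: the limit of > 100000 nM in this assay, at which 1 of the 4 values shown sits.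

All the groups shown at this position are aryl groups held on the same sulfur-linked carbon, so what an amine, a carboxylic acid or a longer chain would do here stays open. Four compounds also cannot separate the arrival of the nitro group from the loss of the chlorines in the change from compound 2 to compound 4.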